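Swapping Chloro for Bromo on a Pyrazoline Core

The source may report more compounds than this note shows. Statements on the series, on what has been measured and on what is new or still open speak of the compounds shown alone.

The measured compounds, with their growth-inhibition values:
- compound 1, `COc1ccc(C2=NN(C(=O)c3cccnc3Cl)C(c3ccc(Cl)cc3)C2)cc1`: 780 nM
- compound 2, `COc1ccc(C2=NN(C(=O)c3cccnc3Cl)C(c3ccc(Br)cc3)C2)cc1`: 3050 nM
- compound 3, `O=C(c1cncc(Br)c1)N1N=C(c2ccc(Cl)cc2)CC1c1ccc(Cl)cc1`: 6090 nM

In a functional assay on WM 266-4 cells (Homo sapiens) for antiproliferative activity, read by MTT assay, with a stated time of 24 h (a lower number here means a stronger inhibitor of growth, a higher number a weaker inhibitor of growth), compound 1 gives 780 nM, while compound 2 gives 3050 nM. The change between them is bromo in place of chloro on an aromatic carbon, and it produced a 3.9-fold higher number from compound 1 to compound 2 (0.59 log units; beyond the scatter). The difference between the core of compound 1 and the core of compound 3 is not broken down here. Compound 3 gives 6090 nM in this assay. Compound 4, `O=C(c1cncc(Br)c1)N1N=C(c2ccc(Cl)cc2)CC1c1ccc(Br)cc1`, differs from compound 3 by bromo in place of chloro on an aromatic carbon, the same change that separates compound 1 from compound 2. On the strength of that earlier step, a 3.9-fold higher number from compound 1 to compound 2 (0.59 log units; beyond the scatter), a similar weakening is expected here, so compound 4 is estimated to show a 2.5-fold higher number from compound 3 to compound 4 (0.39 log units; beyond the scatter) relative to compound 3. Compound 4 is therefore expected to give about 15000 nM in this assay.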

Compound 4, concentration for 50% growth inhibition: 8010 nM
The estimate for compound 4 lay 1.9-fold (0.27 log units) above the measured number, within the range that was stated.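

In this assay, going from 4-chlorophenyl to 4-bromophenyl on the core of compound 3 gives a 1.3-fold higher number from compound 3 to compound 4 (0.12 log units; within the scatter). The same change therefore did not carry over at the same size, and the two steps clearly differ: the same change on two cores in this assay, a 3.9-fold higher number (0.59 log units; beyond the scatter) from compound 1 to compound 2 and a 1.3-fold higher number (0.12 log units; within the scatter) from compound 3 to compound 4, 3.0-fold (0.47 log units) apart, beyond the scatter of two such steps

This shows that the size of the step on one core was a poor guide to its size on the other, but it does not explain why, and two pairs give no general rule for other cores in this series. The compounds shown hold only chloro or bromo at this place on the ring, so it remains open how an amine or a carboxylic acid there would behave on either core. Which part of each core sets the size of the step also remains open.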